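Carbamate ester variation at the piperidine nitrogen: efficacy notes

This account rests on a few compounds, and the source may have more. Where it says the series, first, only, none or still open, it means among the compounds named here.

Measured so far in a functional assay on isolated protein for inhibition of Glucose-dependent insulinotropic receptor (Rattus norvegicus), read by HTRF and cAMP accumulation; a lower number here means a smaller maximal response, a higher number a larger maximal response:
compound 1 `Cc1nc(S(C)(=O)=O)ccc1Oc1ncnc(OC2CCN(C(=O)OC(C)(C)CF)CC2)c1F` gives 95%;
compound 2 `Cc1nc(S(C)(=O)=O)ccc1Oc1ncnc(OC2CCN(C(=O)O[C@@H](C)C(F)(F)F)CC2)c1F` gives 80%;
compound 3 `CCC1(OC(=O)N2CCC(Oc3ncnc(Oc4ccc(S(C)(=O)=O)nc4C)c3F)CC2)CC1` gives 83%.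

Compound 3 stands second highest of the three; its gap to compound 2 is within the scatter, while compound 1 sits above it beyond the scatter. Compound 4 `Cc1nc(S(C)(=O)=O)ccc1Oc1ncnc(OC2CCN(C(=O)OC3COC3)CC2)c1F` is not yet measured. It differs from compound 3 by oxetan-3-yl in place of 1-ethylcyclopropyl on an oxygen next to a carbonyl group.

The bearing steps are those at the same oxygen: a number 15 percentage points lower from compound 1 to compound 2 (beyond the scatter) and a number 12 percentage points lower from compound 1 to compound 3 (beyond the scatter), both modest decreases, and a number 3 percentage points higher from compound 2 to compound 3 (within the scatter), which stayed within the scatter. Groups at this oxygen have so far shifted the largest response only modestly or not at all. For compound 4 no step beyond the scatter is therefore expected, a number 3 percentage points lower from compound 3 to compound 4 (within the scatter), giving an estimated 80% with a range from 65% to 95%.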

Compound 4, largest response reached (reported as efficacy), in percent of the reference or control that the assay uses: 66%
The estimate for compound 4 lay 14 percentage points above the measured number; the range from low to high includes it.
By their numbers in this assay, from the lowest: compound 4; then compounds 2 and 3 (each within the scatter of the next); then compound 1.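

On an oxygen next to a carbonyl group, oxetan-3-yl in place of 1-ethylcyclopropyl gives a number 17 percentage points lower from compound 3 to compound 4 (beyond the scatter) while in place of 1-(trifluoromethyl)ethyl it gives a number 14 percentage points lower from compound 2 to compound 4 (beyond the scatter) and in place of 1-(fluoromethyl)-1-methylethyl it gives a number 29 percentage points lower from compound 1 to compound 4 (beyond the scatter) in the largest response. Compound 4, the only one of the four with a ring oxygen in this group, therefore stands lowest, so this position can lower the response beyond the scatter even relative to compounds 2 and 3. No measurement here accounts for the fall.

From the compounds shown here alone, whether the fall goes with the ring oxygen or with the ring size stays open from one compound. Cyclobutyl and tetrahydrofuran-3-yl at this oxygen would separate the two.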